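Ester variation on the shared core: expectation for compound 3

The compounds below may be only part of what the source reports. "The series", "measured", "known", "first", "only" and "open" are said of these compounds alone.

Among the compounds with values here, compound 1 `C=C1C(=O)O[C@@H]2CC(C)=C([C@@H](C)CCCOC(C)=O)[C@@H](OC(=O)COc3cccc4cccnc34)[C@H]12` gives 8940 nM in a functional assay on HeLa cells (Homo sapiens) for cytotoxicity, read by sulforhodamine B assay, with a stated time of 72 h (a lower number here means a stronger inhibitor, a higher number a weaker inhibitor), the lower of the two numbers measured so far. Within the data shown here, compound 2 `C=C1C(=O)O[C@@H]2CC(C)=C([C@@H](C)CCCOC(C)=O)[C@@H](OC(=O)COc3ccc4c(CC)noc4c3)[C@H]12` gives 21700 nM, and the step of a 2.4-fold higher number from compound 1 to compound 2 (0.39 log units; beyond the scatter) is the only measured step. Compound 3 `C=C1C(=O)O[C@@H]2CC(C)=C([C@@H](C)CCCOC(C)=O)[C@@H](OC(=O)c3cc(OC)c(OC)c(OC)c3)[C@H]12` differs from compound 1 by 3,4,5-trimethoxyphenyl in place of ((quinolin-8-yl)oxy)methyl on a carbonyl carbon. Among the measured compounds shown here, no measured step bears directly on this change, which swaps the whole ((quinolin-8-yl)oxy)methyl for 3,4,5-trimethoxyphenyl on the carbonyl carbon. Without anchor for direction, compound 3 is expected at 9000 nM, with a range from 3000 nM to 27000 nM. The expected step of a 1.0-fold higher number from compound 1 to compound 3 (0.00 log units; within the scatter) is estimated to lie within the scatter.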

Compound 3, half-maximal inhibitory concentration: 6540 nM
Compound 3: the middle estimate sits 1.4-fold (0.14 log units) above what was measured; measured number inside the range.
By their numbers in this assay, from the lowest: compounds 3 and 1 (each within the scatter of the next); then compound 2.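

Exchanging ((quinolin-8-yl)oxy)methyl for 3,4,5-trimethoxyphenyl on the carbonyl carbon gives a 1.4-fold lower number from compound 1 to compound 3 (0.14 log units; within the scatter) in this assay. At this position, an aryl group set directly on the carbonyl carbon, carrying no ring nitrogen, thus reads the same as the quinolinyl ether within the scatter. No available data give a cause for this result. Still open, from the compounds shown here alone, is how an amine or a carboxylic acid in place of 3,4,5-trimethoxyphenyl on the carbonyl carbon would read. Going by these compounds, a longer chain at that place is equally open.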